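Shrinking a Ring Substituent on the Triazole Arm

This account rests on a few compounds, and the source may have more. Where it says the series, first, only, none or still open, it means among the compounds named here.

Of the compounds shown here, three have been measured in an assay on CHO cells for displacement of a labelled ligand from adenosine receptor A3 (Homo sapiens); a higher number here means a weaker inhibitor, a lower number a stronger inhibitor. Compound 1 `CCNC(=O)[C@H]1O[C@@H](n2cnc3c(NC)nc(-n4ccnn4)nc32)[C@H](O)[C@@H]1O` gives 2.1 nM. Compound 2 `CNc1nc(-n2cc(CC3CCCCC3)nn2)nc2c1ncn2[C@@H]1O[C@H](CO)[C@@H](O)[C@H]1O` gives 21.3 nM, and compound 3 `CNc1nc(-c2cn(Cc3cccc(OC)c3)nn2)nc2c1ncn2[C@@H]1O[C@H](CO)[C@@H](O)[C@H]1O` gives 86.1 nM. Among these three numbers compound 2 stands second highest, nearer to compound 3 than to compound 1, and the step up to compound 3 and the step down to compound 1 both lie beyond the usual scatter.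

Compound 4 `CCCCc1cn(-c2nc(NC)c3ncn([C@@H]4O[C@H](CO)[C@@H](O)[C@H]4O)c3n2)nn1` has not yet been measured. It differs from compound 2 in one place: propyl in place of cyclohexyl on a saturated chain carbon bound to an aromatic carbon The same change, cut one bond further out, reads cyclohexylmethyl to butyl.

With no measured step of this kind in hand, the step from compound 2 to compound 4 is expected to be small, of uncertain direction and likely within the scatter, so that compound 4 is estimated at 15 nM, in a range from 4 nM to 60 nM, amounting to a 1.4-fold lower number from compound 2 to compound 4 (0.15 log units; within the scatter).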

Compound 4, inhibition constant: 11.7 nM
Compound 4: the middle estimate sits 1.3-fold (0.11 log units) above what was measured; low and high end bracket the measured number.
By their numbers in this assay, from the lowest: compound 1; then compounds 4 and 2 (each within the scatter of the next); then compound 3.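

In this assay, swapping the ring for an open chain at this position, on a saturated chain carbon bound to an aromatic carbon, gives a 1.8-fold lower number from compound 2 to compound 4 (0.26 log units; within the scatter). So for this one pair, cyclohexylmethyl and butyl cannot be told apart, and the ring with its extra carbons is not required to keep the binding seen with compound 2. No measurement here explains why the two groups read alike. Still open, on these data alone, is how a much shorter chain such as methyl would read, and whether an amine or a carboxylic acid at the end of the butyl chain would be tolerated.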